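Swapping a Hydroxyethyl Arm for Cyclopropyl

A few compounds are considered here, and "the series" means these few. Any claim that something is new, unique, unknown or untested is made for them only; others in the source may bear on it.

Compound 1 `CCCCCCc1cn(C(c2ccccc2)c2cc3cc(Br)ccc3nc2OC)nn1`: -0.97%
Compound 2 `COc1nc2ccc(Br)cc2cc1C(c1ccccc1)n1cc(CCCO)nn1`: 11.3%
Compound 3 `COc1nc2ccc(Br)cc2cc1C(c1ccccc1)n1cc(CCO)nn1`: 0.85%

Of the compounds shown here, three sharing one core have been tested in an ADME assay on HeLa cells (Homo sapiens) for cytotoxicity, read by sulforhodamine B assay, with a stated time of 48 h, tested at 10 uM; a higher number here means more inhibition at the concentration tested (going by the name of the read-out), a lower number less inhibition. In this assay compound 3 gives 0.85%, a number within the scatter of compound 1, which gives -0.97%, while compound 2 stands apart: the step of a number 10.5 percentage points lower from compound 2 to compound 3 (beyond the scatter) is beyond the scatter, so compound 3 sits with compound 1 and under compound 2.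

Compound 4 `COc1nc2ccc(Br)cc2cc1C(c1ccccc1)n1cc(C2CC2)nn1` is the next compound. cyclopropyl in place of 2-hydroxyethyl on an aromatic carbon

Going by the values given here, no measured step involves a cyclopropyl group, so the closest guide is the step of a number 1.8 percentage points higher from compound 1 to compound 3 (within the scatter), in which a plain hydrocarbon chain was exchanged for a chain bearing a hydroxy group, and the number barely moved. The step of a number 12.3 percentage points higher from compound 1 to compound 2 (beyond the scatter) was larger, but it leads to compound 2 rather than to compound 3. The change from compound 3 to compound 4 again trades a hydroxy-bearing arm for a plain hydrocarbon, so a step within the scatter is expected, a number 0.2 percentage points higher from compound 3 to compound 4 (within the scatter).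

Compound 4 is therefore estimated at 1% in this assay, expected to fall between -9% and 12%.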

Compound 4, a percentage reported as inhibition, at one concentration (the size of the read-out at that concentration, not a potency): -5.84%
Estimate against measurement, compound 4: 6.8 percentage points above; low and high end bracket the measured number.
By their numbers in this assay, from the lowest: compounds 4, 1 and 3 (each within the scatter of the next); then compound 2.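

In this assay the exchange of 2-hydroxyethyl for cyclopropyl on this aromatic carbon of the triazole-bearing arm removes a hydrogen-bond donor and a hydrogen-bond acceptor and adds a three-membered ring, yet it gives a number 6.7 percentage points lower from compound 3 to compound 4 (within the scatter) and so leaves the number within the usual scatter. Hexyl and cyclopropyl also cannot be told apart at this position, with a number 4.9 percentage points lower from compound 1 to compound 4 (within the scatter) on that comparison, which means that a ring and a long hydrocarbon chain read alike here, and 2-hydroxyethyl reads alike with both. Only 3-hydroxypropyl stands apart, with a number 17.1 percentage points lower from compound 2 to compound 4 (beyond the scatter) as the largest step in the set, and nothing measured on these compounds accounts for its separate place.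

The compounds shown leave open whether the higher number of compound 2 belongs to the hydroxy group at that chain length, which a 4-hydroxybutyl arm or a 3-methoxypropyl arm would help to settle. They also leave open whether an amine or a carboxylic acid at the end of the arm, or a larger ring such as cyclohexyl, would move the number at all.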